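The source may hold more compounds than are shown below. What is called first, only, known or untested is meant among the compounds shown, and "the series" means these compounds.

Compound 1 `COc1cc(OC)c(OC)cc1/C=C/C(=O)c1ccc(Cl)cc1` gives in a functional assay on SW982 cells (Homo sapiens) for inhibition, read by MTT assay, with a stated time of 72 h (on this read-out higher numbers stand for weaker inhibition and lower numbers for stronger inhibition), a value of 58500 nM. Compound 3 `COc1cc(OC)c(OC)cc1/C=C/C(=O)c1ccc(O)cc1` gives in this assay 155000 nM. The step of a 2.6-fold higher number from compound 1 to compound 3 (0.42 log units; beyond the scatter) comes with the change (hydroxy in place of chloro on an aromatic carbon). Compound 2 `COc1cc(OC)c(-c2cc(=O)c3cc(Cl)ccc3o2)cc1OC` carries a different core, and the difference between the two cores is not broken down here. In this assay compound 2 reaches only a limit, > 150000 nM, which is the limit noted as the limit of > 150000 nM in this assay, at which 1 of the 3 values shown sits. Compound 4 `COc1cc(OC)c(-c2cc(=O)c3cc(O)ccc3o2)cc1OC` carries the same kind of change, (hydroxy in place of chloro on an aromatic carbon); here the place is part of a fused or bridged system of two rings, meta to a fused ring and para to a fused ring, whereas in compound 3 it is para to a large group. Given that the step of a 2.6-fold higher number from compound 1 to compound 3 (0.42 log units; beyond the scatter) raised the number, compound 4 is expected to show a step that the limit leaves unreadable from compound 2 to compound 4. Compound 4 is therefore estimated at 300000 nM, between 150000 nM and 1000000 nM, most likely again as a limit.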

Compound 4, half-maximal inhibitory concentration: > 150000 nM
Compound 4 was reported as a limit; the forecaster's own chance of this, stated with the estimate: 85%; the middle value is on the limit's open side.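

Compound 2 and compound 4 both stand only as limits in this assay, so no step can be read between them: the limit of > 150000 nM in this assay, at which 2 of the 4 values shown sit.

The compounds shown leave open whether hydroxy in place of chloro changes the number on the core of compound 2.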